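Lengthening a Chain on a Hydroxylated Analogue

A few compounds are considered here, and "the series" means these few. Any claim that something is new, unique, unknown or untested is made for them only; others in the source may bear on it.

The series rests on one shared core, carried by compound 1 `CN(C)C(=O)c1cc2cnc(Nc3ccc(C(=O)NCCCCN=C=S)cc3)nc2n1C1CCCC1` and compound 2 `CN(C)C(=O)c1cc2cnc(Nc3ccc(C(=O)NCCCN=C=S)cc3O)nc2n1C1CCCC1`. In a functional assay on A549 cells (Homo sapiens) for inhibition, read by CCK-8 assay, with a stated time of 72 h, tested at 10 uM (a lower number here means a weaker effect, a higher number a stronger effect of the compound at the concentration tested), compound 1 gives 102%, while compound 2 gives 73% in this assay, the lower of the two numbers on record, and its gap to compound 1 lies beyond the usual scatter. Compound 3 `CN(C)C(=O)c1cc2cnc(Nc3ccc(C(=O)NCCCCN=C=S)cc3O)nc2n1C1CCCC1` has not yet been measured in this assay. It differs from compound 2 in one place: a group of 4 heavy atoms (2 carbon, 1 nitrogen, 1 sulfur; no ring) in place of a group of 3 heavy atoms (1 carbon, 1 nitrogen, 1 sulfur; no ring), on a saturated chain carbon, three bonds along the chain from an amide-type nitrogen. Among the measured compounds shown here, no step between two measured compounds is available for this change, so the expectation rests on the spread of the two values in hand. Compound 3 is expected to give 88% in this assay, within a range from 68% to 105%. That estimate means a step of a number 15 percentage points higher from compound 2 to compound 3 (beyond the scatter), a gain beyond the scatter, falling between the values of compound 2 and compound 1.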

Compound 3, a percentage reported as inhibition, at one concentration (the size of the read-out at that concentration, not a potency): 41.7%
The estimate for compound 3 lay 46.3 percentage points above the measured number; measured number below the stated range.
By their numbers in this assay, from the lowest: compound 3; then compound 2; then compound 1.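

Compound 1 and compound 2 differ in two places, so they could not separate the chain from the hydroxy group, but compound 3 now gives a single-change step for each. In this assay, the group of 4 heavy atoms in place of the group of 3 heavy atoms on the hydroxylated analogue brings a number 31.3 percentage points lower from compound 2 to compound 3 (beyond the scatter) and hydroxy in place of hydrogen on an aromatic carbon, with the chain of compound 1 kept, brings a number 60.3 percentage points lower from compound 1 to compound 3 (beyond the scatter), so each single change leading to compound 3 lowers the number. No supporting measurement on hand accounts for either step.

The compounds shown leave open whether the chain step would hold without the hydroxy group on the aromatic ring. They also leave open whether a longer chain would lower the number further, or how methoxy in place of hydroxy would read.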